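Swapping Chloro for Cyclopropyl on the Aryl Ring

A few compounds are considered here, and "the series" means these few. Any claim that something is new, unique, unknown or untested is made for them only; others in the source may bear on it.

Of the compounds shown here, three sharing one core have been measured in a functional assay on CHO cells for antagonist activity at Glucagon receptor (Homo sapiens), read by cAMP accumulation, with stated times of 30 min and 45 min; a lower number here means a stronger inhibitor, a higher number a weaker inhibitor. Compound 1 `CC1(CC[C@H](c2ccc(C(=O)NCc3nn[nH]n3)cc2)N2C(=O)C(c3cc(Cl)cc(Cl)c3)=N[C@]23CC[C@@H](C(C)(C)C)CC3)CC1` gives 100 nM. Compound 2 `C[C@H](c1ccc(C(=O)NCCC(=O)O)cc1)N1C(=O)C(c2cccc(Cl)c2)=N[C@]12CC[C@@H](C(C)(C)C)CC2` gives 480 nM, and compound 3 `CC(C)(C)[C@H]1CC[C@]2(CC1)N=C(c1ccc(Cl)c(Cl)c1)C(=O)N2Cc1ccc(C(=O)NCCC(=O)O)cc1` gives 1600 nM. Compound 2 thus sits second highest of the three: compound 3 shows a higher number and compound 1 a lower one, both gaps beyond the usual scatter. Compound 4 `C[C@H](c1ccc(C(=O)NCCC(=O)O)cc1)N1C(=O)C(c2cccc(C3CC3)c2)=N[C@]12CC[C@@H](C(C)(C)C)CC2` differs from compound 2 in a single place: cyclopropyl in place of chloro on an aromatic carbon. Within the data shown here, no measured pair in this set shows the same swap, so its effect cannot be read from the data. Cyclopropyl in place of chloro is expected to move the number little, with no step beyond the scatter, so the estimated step is a 1.2-fold lower number from compound 2 to compound 4 (0.08 log units; within the scatter). Compound 4 is therefore estimated at 400 nM, within 150 nM to 1300 nM.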

Compound 4, half-maximal inhibitory concentration: 340 nM
Compound 4: the middle estimate sits 1.2-fold (0.07 log units) above what was measured; the measured number falls inside the stated range.
By their numbers in this assay, from the lowest: compound 1; then compounds 4 and 2 (each within the scatter of the next); then compound 3.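

Cyclopropyl in place of chloro on this aromatic carbon gives a 1.4-fold lower number from compound 2 to compound 4 (0.15 log units; within the scatter) in this assay. The position therefore accepts a group of three heavy atoms with a three-membered ring in place of a single chlorine, and the two compounds cannot be told apart by their numbers. No measurement here explains this result.

As far as these compounds go, whether an amine, a methoxy group or a longer chain would fare the same on this carbon stays open. So does whether cyclopropyl could replace chloro on the rings of compound 1 and compound 3 with a similar result.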